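This account rests on a few compounds, and the source may have more. Where it says the series, first, only, none or still open, it means among the compounds named here.

Measured in an assay on isolated protein for inhibition of Maltase-glucoamylase (Homo sapiens), with a stated time of 15 min; a higher number here means a weaker inhibitor, a lower number a stronger inhibitor:
- compound 1, `O=C(N/N=C/c1cccc(O)c1O)c1ccc(-c2nc3ccccc3s2)cc1`: 11200 nM
- compound 2, `O=C(N/N=C/c1ccc(Cl)cc1)c1ccc(-c2nc3ccccc3s2)cc1`: 5310 nM

Within the data shown here, compound 2 holds the lowest of the two numbers in this assay; the only neighbour is compound 1, and the step of a 2.1-fold lower number from compound 1 to compound 2 (0.32 log units; beyond the scatter) is modest but beyond the scatter. Compound 3, `O=C(N/N=C/c1cc(O)ccc1O)c1ccc(-c2nc3ccccc3s2)cc1`, is not yet measured. It differs from compound 2 in one place: 2,5-dihydroxyphenyl in place of 4-chlorophenyl on a carbon with a double bond to nitrogen. Among the measured compounds shown here, the one step that bears on this change is the reverse of it in kind, a 2.1-fold lower number from compound 1 to compound 2 (0.32 log units; beyond the scatter), where a dihydroxyphenyl gave way to the chlorophenyl and the number fell. Returning to a dihydroxyphenyl, now the 2,5-pattern, is therefore expected to move the number back up by a step of similar, modest size, a 1.9-fold higher number from compound 2 to compound 3 (0.27 log units; within the scatter). For the measured compounds named here, for compound 3 the expected value in this assay is 10000 nM, with a range from 4500 nM to 25000 nM; the 2,5-pattern itself has no measured precedent here, so the range is kept wide.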

Compound 3, half-maximal inhibitory concentration: 11900 nM
Estimate against measurement, compound 3: 1.2-fold (0.08 log units) below; measured number inside the range.
By their numbers in this assay, from the lowest: compound 2; then compounds 1 and 3 (each within the scatter of the next).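

In this assay, the placing of the two hydroxyl groups on the ring carried by the carbon with a double bond to nitrogen shows no effect that can be read: a 1.1-fold higher number from compound 1 to compound 3 (0.03 log units; within the scatter), from 2,3-dihydroxyphenyl to 2,5-dihydroxyphenyl. The gap to 4-chlorophenyl therefore now holds for two dihydroxyphenyl patterns rather than one, with a 2.2-fold higher number from compound 2 to compound 3 (0.35 log units; beyond the scatter) as the second modest step beyond the scatter. Nothing available explains this gap between 4-chlorophenyl and the dihydroxyphenyl groups.

Open, going by these compounds, is whether the lower number of compound 2 goes with the chlorine itself or with the absence of hydroxyl groups, which a plain phenyl or a single hydroxyphenyl could separate. Also open, on these data alone, is how a ring bearing an amine or a carboxylic acid would read at this position.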